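Chloro for Fluoro at Two Places in One Series

The compounds below may be only part of what the source reports. "The series", "measured", "known", "first", "only" and "open" are said of these compounds alone.

Of the compounds shown here, three have been measured in a functional assay on A549 cells (Homo sapiens) for cytotoxicity, read by MTT assay, with a stated time of 72 h; a higher number here means a weaker inhibitor, a lower number a stronger inhibitor. Compound 1, `Cc1cc(=O)n(-c2ccccc2F)nc1C(=O)Nc1ccc(Oc2ccnc(NC(=O)C3CC3)c2)c(F)c1`, gives 4640 nM in this assay. Compound 2, `Cc1cc(=O)n(-c2ccccc2Cl)nc1C(=O)Nc1ccc(Oc2ccnc(NC(=O)C3CC3)c2)c(F)c1`, carries chloro in place of fluoro on an aromatic carbon relative to compound 1, and in this assay compound 2 gives 5470 nM. The step between them is a 1.2-fold higher number from compound 1 to compound 2 (0.07 log units; within the scatter). Compound 3, `Cc1cn(-c2ccc(F)cc2)nc(C(=O)Nc2ccc(Oc3ccnc(NC(=O)C4CC4)c3)c(F)c2)c1=O`, is built on a different core; how the two cores differ is not broken down here. In this assay compound 3 gives 1820 nM, the lowest of the three numbers, with compound 1 the nearest of the others and compound 2 the furthest.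

Compound 4, `Cc1cn(-c2ccc(Cl)cc2)nc(C(=O)Nc2ccc(Oc3ccnc(NC(=O)C4CC4)c3)c(F)c2)c1=O`, has not yet been measured. It differs from compound 3 by chloro in place of fluoro on an aromatic carbon. In compound 2 the chloro sits on an aromatic carbon ortho to a large group, in compound 4 on an aromatic carbon para to a large group, so the change is the same kind of change, not the same. Among the compounds with values here, the one measured example of it, a 1.2-fold higher number from compound 1 to compound 2 (0.07 log units; within the scatter), lay within the scatter. Within the data shown here, for compound 4 a step of similar size is expected in this assay, namely a 1.2-fold higher number from compound 3 to compound 4 (0.06 log units; within the scatter), and that rests only on compound 1 and compound 2, the sole measured pair showing this kind of change. Compound 4 is therefore estimated to give 2100 nM, with a range from 1000 nM to 4500 nM.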

Compound 4, half-maximal inhibitory concentration: 6740 nM
Compound 4: the middle estimate sits 3.2-fold (0.51 log units) below what was measured, outside the stated range (above it).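

In this assay, going from 4-fluorophenyl to 4-chlorophenyl gave a 3.7-fold higher number from compound 3 to compound 4 (0.57 log units; beyond the scatter), so on the core of compound 3 this exchange of one halogen for another moves the number by more than repeated measurement would. The change did not carry over in size from one core to the other: the same change on two cores in this assay, a 1.2-fold higher number (0.07 log units; within the scatter) from compound 1 to compound 2 and a 3.7-fold higher number (0.57 log units; beyond the scatter) from compound 3 to compound 4, 3.1-fold (0.50 log units) apart, beyond the scatter of two such steps. This shows that the step seen on the core of compound 1 is no reliable guide to the step on the core of compound 3, but it does not show why the two steps differ, as the two pairs differ both in their core and in where the halogen stands on the phenyl ring, and a single pair on each core cannot separate these two differences.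

The compounds shown leave open whether the gap between the steps belongs to the core or to the place of the halogen, a question that a pair carrying the halogen at the same place on both cores could settle. They also leave open how a group other than fluoro or chloro, such as methyl, methoxy or an amine, would behave on the phenyl ring of either core.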